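Cytotoxicity notes: aryl substituent swaps on a shared core

The source may hold more compounds than are shown below. What is called first, only, known or untested is meant among the compounds shown, and "the series" means these compounds.

Measured in a functional assay on A549 cells (Homo sapiens) for cytotoxicity; on this read-out lower numbers stand for stronger inhibition and higher numbers for weaker inhibition:
compound 1, `Cc1ccc(C2CNC(=O)N2S(=O)(=O)c2ccc3c(c2)CCC3)cc1`, gives 90300 nM
compound 2, `O=C1NC(c2ccc(Br)cc2)CN1S(=O)(=O)c1ccc2c(c1)CCC2`, gives 33900 nM
compound 3, `Cc1ccc(C2CN(S(=O)(=O)c3ccc4c(c3)CCC4)C(=O)N2)cc1`, gives 99200 nM

Compound 3 and compound 1 lie within the scatter of one another at the upper end of these numbers; compound 2 sits beyond the scatter below both. Among the compounds with values here, the one step bearing on the next compound is a 2.9-fold higher number from compound 2 to compound 3 (0.47 log units; beyond the scatter). Compound 4, `O=C1NC(c2ccc(Cl)cc2)CN1S(=O)(=O)c1ccc2c(c1)CCC2`, differs from compound 3 by chloro in place of methyl on an aromatic carbon. Chloro, like bromo, is a halogen in the same place, so a lower number is expected for compound 4 in this assay, about as large as the step to compound 3 but reversed, on one step of evidence only. Compound 4 is expected to show a 2.2-fold lower number from compound 3 to compound 4 (0.34 log units; beyond the scatter). The estimate for compound 4 is 45000 nM, within 20000 nM to 100000 nM.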

Compound 4, half-maximal inhibitory concentration: 86300 nM
Beside the measured number, compound 4's estimate is 1.9-fold (0.28 log units) below it; measured number inside the range.
By their numbers in this assay, from the lowest: compound 2; then compounds 4, 1 and 3 (each within the scatter of the next).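

In this assay the change from 4-methylphenyl to 4-chlorophenyl leaves the two compounds within the scatter (a 1.1-fold lower number from compound 3 to compound 4 (0.06 log units; within the scatter)), so this position does not separate chloro from methyl. Chloro and bromo do not read alike here (a 2.5-fold higher number from compound 2 to compound 4 (0.41 log units; beyond the scatter)), so the earlier step from bromo to methyl does not extend to halogens as a class. No evidence at hand accounts for the gap between bromo and chloro.

Open, from the compounds shown here alone, is whether fluoro would read with chloro or with bromo at this place. Also open, going by these compounds, is how an amine or a carboxylic acid there would read.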